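Moving the fluorine on the phenyl ring of compound 2

A few compounds are considered here, and "the series" means these few. Any claim that something is new, unique, unknown or untested is made for them only; others in the source may bear on it.

Measured compounds in an assay on a protein complex for positive allosteric modulation of Neuronal acetylcholine receptor; alpha4/beta2 (Homo sapiens); a higher number here means a larger maximal response, a lower number a smaller maximal response:
Compound 1, `CN(Cc1cc(-c2ccccc2Cl)no1)C(=O)C1CCNCC1`, gives 41%.
Compound 2, `Fc1cccc(Cl)c1-c1cc(-c2cnn(C3CCNCC3)c2)on1`, gives 60%.
Compound 3, `Cc1c(-c2cc(-c3c(F)cccc3Cl)no2)cnn1C1CCNCC1`, gives 66%.

Among these three numbers compound 2 stands second highest. Its nearest neighbour is compound 3, where the step of a number 6 percentage points higher from compound 2 to compound 3 (within the scatter) lies within the scatter and so does not separate the two; its furthest is compound 1, which gives the lower of the three numbers and lies beyond the scatter from compound 2.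

Compound 4, `Fc1ccc(-c2cc(-c3cnn(C4CCNCC4)c3)on2)c(Cl)c1`, has not yet been measured. It differs from compound 2 in one place: 2-chloro-4-fluorophenyl in place of 2-chloro-6-fluorophenyl on an aromatic carbon. The two compounds have the same atoms, joined differently.

Within the data shown here, only one measured step is available, from compound 2 to compound 3, and it adds a methyl on a ring carbon rather than rearranging the phenyl ring, so it does not bear on this change. Among the measured compounds shown here, no measured pair shows what happens when the fluorine is moved. Without such a comparison, the step of a number 3 percentage points lower from compound 2 to compound 4 (within the scatter) is expected to stay within the scatter, in no set direction. Compound 4 is therefore estimated to give 57%, with a range from 38% to 76%.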

Compound 4, largest response reached (reported as efficacy), in percent of the reference or control that the assay uses: 56%
Compound 4: middle estimate off by 1 percentage points, on the high side; the range from low to high includes it.
By their numbers in this assay, from the lowest: compound 1; then compounds 4, 2 and 3 (each within the scatter of the next).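

In this assay, putting 2-chloro-4-fluorophenyl in place of 2-chloro-6-fluorophenyl on the aromatic carbon next to the ring nitrogen gives a number 4 percentage points lower from compound 2 to compound 4 (within the scatter), a step too small to separate the two compounds. Among these compounds, this is the first pair here that changes the phenyl group itself, whereas the earlier step concerned a methyl on a ring carbon elsewhere in the molecule. It shows that, with the atoms unchanged and only the fluorine placed differently, the maximal response stays within normal repeat variation, and no data shown here explain why these two arrangements read alike.

On these data alone, what remains open is whether a different group in place of the fluorine, such as a methoxy group, a nitrile or an amine, would carry the response beyond the scatter, since this pair only moves one atom within the same set of atoms. As far as these compounds go, it is also open whether 2-chloro-4-fluorophenyl would behave the same way alongside the methyl group of compound 3, because a single pair cannot show whether the result holds on a changed core.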